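The compounds below may be only part of what the source reports. "The series", "measured", "known", "first", "only" and "open" are said of these compounds alone.

Measured so far in an in vitro functional assay on Sf9 cells for agonist activity at histamine H2 receptor (Cavia porcellus); on this read-out lower numbers stand for smaller maximal responses and higher numbers for larger maximal responses:

Compound 1, `Cc1nc(N)sc1CCCN/C(N)=N/C(=O)CCCCCCCCC(=O)/N=C(\N)NCCCc1sc(N)nc1C`, gives 0.79.
Compound 2, `Cc1nc(N)sc1CCCN/C(N)=N/C(=O)CCCCCCCCCCCCCCCCCCCCC(=O)/N=C(\N)NCCCc1sc(N)nc1C`, gives 0.58.
Compound 3, `N/C(=N\C(=O)CCCCCCCCC(=O)/N=C(\N)NCCCc1cnc(N)s1)NCCCc1cnc(N)s1`, gives 0.94.

Compound 3 stands highest of the three: the nearest value is that of compound 1, lower by a margin beyond the scatter, and the furthest is that of compound 2, lower still. The next compound, compound 4, is `Cc1nc(N)sc1CCCN/C(N)=N/C(=O)CCCCCCCCC(=O)/N=C(\N)NCCCc1cnc(N)s1`. It differs from compound 3 in one place: methyl in place of hydrogen on an aromatic carbon. Going by the values given here, no measured pair in this set shows that single change on its own; compound 1 carries the methyl on both of its rings and compound 3 on neither, and compound 1 sits below compound 3, but those two differ in two places, so their gap is not a clean step. Compound 4 carries the methyl on one ring only, so it is expected to fall between compound 1 and compound 3, with a small downward step a number 0.070 lower from compound 3 to compound 4 (within the scatter) that may lie within the scatter. Compound 4 is therefore estimated at 0.87 in this assay, with a range from 0.75 to 0.97.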

Compound 4, intrinsic activity: the largest response reached, as a fraction of the reference agonist's: 0.89
The estimate for compound 4 lay 0.020 below the measured number, within the range that was stated.
By their numbers in this assay, from the lowest: compound 2; then compounds 1, 4 and 3 (each within the scatter of the next, the first and the last beyond it).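

In this assay, going by these compounds alone, methyl in place of hydrogen on the aromatic carbon next to the ring nitrogen, which turns one 2-amino-1,3-thiazol-5-yl into 2-amino-4-methyl-1,3-thiazol-5-yl, gives a number 0.050 lower from compound 3 to compound 4 (within the scatter), the first reading of this change on its own. The same exchange on the other ring, read as hydrogen in place of methyl, gives a number 0.10 higher from compound 1 to compound 4 (within the scatter), so neither single step carries the maximal response beyond the scatter. Nothing available here accounts for the size of these steps.

The compounds shown leave open what an ethyl group, a chlorine atom or an amine on this carbon would do to the maximal response. They also leave open whether the methyl step would stay this small on the longer chain of compound 2.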